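The source may hold more compounds than are shown below. What is called first, only, known or untested is meant among the compounds shown, and "the series" means these compounds.

Compound 2 `O=S(=O)(Nc1ccc(-c2nc3ccccc3o2)cc1)c1cccc(Cl)c1` is a sulfonamide with a 3-chlorophenyl group on the sulfonyl sulfur. In an assay on isolated protein for inhibition of malate dehydrogenase, mitochondrial (Sus scrofa), with stated times of 45 min and 30 min (a lower number here means a stronger inhibitor, a higher number a weaker inhibitor), compound 2 gives > 63000 nM, which is a limit of the assay and not a number. Two related compounds were measured alongside it. Compound 1 `O=S(=O)(Nc1ccc2oc(-c3ccccc3)nc2c1)c1ccc(Cl)c(Cl)c1` gives in this assay > 63000 nM, again a limit. Compound 3 `O=S(=O)(Nc1ccc2oc(-c3ccccc3)nc2c1)c1cccc(F)c1` gives in this assay > 63000 nM, also a limit. Among the measured compounds shown here, the only single-point step among them, a step that the two limits leave unreadable from compound 1 to compound 3, is therefore unreadable, since both ends sit at the limit of > 63000 nM in this assay, at which 3 of the 3 values shown sit.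

Compound 4 `Cc1ccc(S(=O)(=O)Nc2ccc(-c3nc4ccccc4o3)cc2)cc1` differs from compound 2 by 4-methylphenyl in place of 3-chlorophenyl on a sulfonyl sulfur. For the measured compounds named here, no measured step bears directly on this exchange, and the one step that was measured gives no readable size. Going by the values given here, what the three compounds do show is that every value so far lies at the limit, so there is no sign that this kind of change moves the number into the measurable range. Compound 4 is therefore expected to give 100000 nM, with a range from 30000 nM to 400000 nM. The step this implies, a step that the limit leaves unreadable from compound 2 to compound 4, is an estimate only, and the most likely outcome is another limit.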

Compound 4, half-maximal inhibitory concentration: > 63000 nM
Compound 4 gave a limit, no number (the forecaster's own chance of this, stated with the estimate: 80%); the middle value is on the limit's open side.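

Compound 2 and compound 4 both give a limit and not a number, so the step between them cannot be read. The compounds shown leave open whether any group on the sulfonyl sulfur would give a measurable value in this assay, since all of them sit at one limit: the limit of > 63000 nM in this assay, at which 4 of the 4 values shown sit.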